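Cyclohexyl to 4-methoxyphenyl on a weak naphthoquinone-like series

The source may hold more compounds than are shown below. What is called first, only, known or untested is meant among the compounds shown, and "the series" means these compounds.

Measured compounds:
compound 1, `COc1ccc(CCC2=C(Cl)C(=O)c3cc(OC)cc(OC)c3C2=O)cc1`, 83100 nM in a functional assay on A549 cells (Homo sapiens) for antiproliferative activity, read by MTT assay, with a stated time of 48 h; on this read-out higher numbers stand for weaker inhibition and lower numbers for stronger inhibition
compound 2, `COC1=C(CCC2CCCCC2)C(=O)c2c(OC)cc(OC)cc2C1=O`, > 100000 nM in this assay

Compound 2 sits at a limit of this assay (the limit of > 100000 nM in this assay, at which 1 of the 2 values shown sits), so only a bound is known. Compound 3, `COC1=C(CCc2ccc(OC)cc2)C(=O)c2c(OC)cc(OC)cc2C1=O`, differs from compound 2 by 4-methoxyphenyl in place of cyclohexyl on a saturated chain carbon, two bonds along the chain from a double-bonded ring carbon. Among the compounds with values here, no measured step covers this change; the step from compound 2 to compound 3 is expected to be small, if any, and the estimate is an at least 1.1-fold lower number from compound 2 to compound 3 (0.04 log units; that floor lies within the scatter). Compound 3 is expected to give 90000 nM, within 40000 nM to 200000 nM.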

Compound 3, half-maximal inhibitory concentration: > 100000 nM
Compound 3 was reported as a limit; the forecaster's own chance of this, stated with the estimate: 45%; middle value at least 1.1-fold (0.04 log units) from the limit.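

In this assay compound 3 gives > 100000 nM, which is a limit and not a number. The exchange of cyclohexyl for 4-methoxyphenyl cannot be read, since compound 2 and compound 3 both stand at a limit: the limit of > 100000 nM in this assay, at which 2 of the 3 values shown sit. Methoxy in place of chloro on a double-bonded ring carbon gives an at least 1.2-fold higher number from compound 1 to compound 3 (0.08 log units; that floor lies within the scatter), a bound that does not settle how large this change is. Going by these compounds, what stays open is whether an amine or a carboxylic acid at the end of the chain, or a longer chain, would bring the methoxy compounds off the limit.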